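Methoxy for Chloro on the Phenoxy Ring of Compound 2

The source may report more compounds than this note shows. Statements on the series, on what has been measured and on what is new or still open speak of the compounds shown alone.

Compound 1 `Cc1nn(C)c(Oc2ccc(Cl)cc2)c1/C=N\OCc1c(Cl)c(-c2ccc(F)cc2)nn1C`: 80% in a functional assay on SMMC-7721 cells (Homo sapiens) for inhibition, read by MTT assay, with a stated time of 72 h, tested at 25 uM; on this read-out higher numbers stand for more inhibition at the one concentration tested (going by the name of the read-out) and lower numbers for less inhibition
Compound 2 `Cc1nn(C)c(Oc2ccc(Cl)cc2)c1/C=N\OCc1c(Cl)c(-c2ccc(Cl)cc2)nn1C`: 80% in this assay

Compound 2 stands level with compound 1 on the numbers shown, the step of no change at the digits printed from compound 1 to compound 2 (within the scatter) lying within the scatter. Compound 3 `COc1ccc(Oc2c(/C=N\OCc3c(Cl)c(-c4ccc(Cl)cc4)nn3C)c(C)nn2C)cc1` differs from compound 2 by methoxy in place of chloro on an aromatic carbon. Among the measured compounds shown here, the single measured step exchanged one halogen for another on the other aromatic ring, so no measured step bears directly on methoxy in place of chloro at this position. With only a flat halogen swap to go by, no step beyond the scatter is expected, a number 5 percentage points lower from compound 2 to compound 3 (within the scatter). Compound 3 is therefore estimated at 75%, between 55% and 90%.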

Compound 3, a percentage reported as inhibition, at one concentration (the size of the read-out at that concentration, not a potency): 80%
Beside the measured number, compound 3's estimate is 5 percentage points below it; the range from low to high includes it.
By their numbers in this assay, from the lowest: compounds 1, 2 and 3 (each within the scatter of the next).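

Methoxy in place of chloro, para to a large group on the phenoxy ring, gave no change at the digits printed from compound 2 to compound 3 (within the scatter) in this assay. Among the compounds shown here, this is the first measured step at this position, and it shows that 4-methoxyphenoxy and 4-chlorophenoxy cannot be told apart on this read-out at the one concentration tested. Nothing available gives a reason for this result.

As far as these compounds go, whether an amine or a carboxylic acid at this position would leave the read-out unchanged remains open. So does whether these compounds would separate at a lower concentration.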